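The compounds below may be only part of what the source reports. "The series", "measured", "known", "first", "only" and "open" are said of these compounds alone.

In a functional assay on MGC-803 cells (Homo sapiens) for antiproliferative activity, read by CCK-8 assay, with a stated time of 72 h (a lower number here means a stronger inhibitor, a higher number a weaker inhibitor), the measured compounds are these:

Compound 1 `Nc1ccccc1NC(=O)c1ccc(COc2ccc(Br)cc2)cc1` gives > 32000 nM (a limit)
Compound 2 `O=C(NO)c1ccc(COc2ccccc2)cc1` gives "not determined" (no result reported) (no result)
Compound 3 `Nc1ccccc1NC(=O)c1ccc(COc2ccc(Cl)cc2)cc1` gives > 32000 nM (a limit)

Compound 3 therefore stands at a limit and not at a number. The series offers only the limit of > 32000 nM in this assay, at which 2 of the 3 values shown sit, and no measured value to work from.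

Compound 4 `Nc1ccccc1NC(=O)c1ccc(COc2ccccc2)cc1` is still unmeasured. It carries hydrogen in place of chloro on an aromatic carbon, para to a large group hydrogen in place of chloro on an aromatic carbon and so turns 4-chlorophenoxy into phenoxy.

Among the compounds with values here, one measured step bears on this, the change of chloro in place of bromo on an aromatic carbon. That step is a step that the two limits leave unreadable from compound 1 to compound 3 and it gives no size to carry over. No step beyond the scatter is therefore expected in this assay and no direction can be argued. The expected step is a step that the limit leaves unreadable from compound 3 to compound 4 and it remains an estimate. The estimated value for compound 4 is 40000 nM with an expected range of 15000 nM to 100000 nM and a report as a bare limit is likely.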

Compound 4, half-maximal inhibitory concentration: 5670 nM
Beside the measured number, compound 4's estimate is 7.1-fold (0.85 log units) above it; the whole stated range lies above it.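

In this assay, hydrogen in place of chloro on the aromatic carbon para to a large group gives an at least 5.6-fold lower number from compound 3 to compound 4 (0.75 log units; beyond the scatter), and hydrogen in place of bromo at that carbon gives an at least 5.6-fold lower number from compound 1 to compound 4 (0.75 log units; beyond the scatter). This position therefore does affect the read-out, which the exchange of one halogen for the other could not show, since that step cannot be read. Compound 1 and compound 3 each stand at a limit and not at a number, so both steps give only a minimum size: the limit of > 32000 nM in this assay, at which 2 of the 4 values shown sit.

Going by these compounds, how far compound 1 and compound 3 truly lie from compound 4 stays open, as does any order between those two. Also open, on these data alone, is whether a fluoro, methyl or methoxy group at this carbon would read like hydrogen or like chloro and bromo.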